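A few compounds are considered here, and "the series" means these few. Any claim that something is new, unique, unknown or untested is made for them only; others in the source may bear on it.

Measured so far, in an assay on Huh-7 cells for agonist activity at Bile acid receptor (Homo sapiens), read by a luciferase reporter; on this read-out lower numbers stand for an effect already at smaller amounts and higher numbers for an effect only at larger amounts of compound:

Compound 1, `CCC(CC)n1c(-c2ccc(OCc3c(-c4c(Cl)cccc4Cl)noc3C(C)C)cc2F)nc2ccc(C(=O)O)cc21`: compound 1 gives 1.3 nM
Compound 2, `CCC(CC)n1c(-c2ccc(OCc3c(-c4c(Cl)cccc4Cl)noc3C(C)C)cc2)nc2ccc(C(=O)O)cc21`: compound 2 gives 0.8 nM
Compound 3, `CC(C)c1onc(-c2c(Cl)cccc2Cl)c1COc1ccc(-c2nc3ccc(C(=O)O)cc3n2C2CC2)cc1`: compound 3 gives 16.5 nM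

Compound 2 has the lowest of the three numbers in this assay. Its nearest neighbour is compound 1, and that gap, a 1.6-fold lower number from compound 1 to compound 2 (0.21 log units; within the scatter), is within the scatter, so the two cannot be ranked against each other. The far end is compound 3, reached by a 21-fold higher number from compound 2 to compound 3 (1.31 log units; beyond the scatter), a large step that changes only the group on the aromatic nitrogen of the shared core.

Compound 4, `CCCC(CCC)n1c(-c2ccc(OCc3c(-c4c(Cl)cccc4Cl)noc3C(C)C)cc2)nc2ccc(C(=O)O)cc21`, is not yet measured. It differs from compound 2 by 1-propylbutyl in place of pentan-3-yl on an aromatic nitrogen. This change sits at the same aromatic nitrogen where the step from compound 2 to compound 3 acted, but it goes the other way: it enlarges the branched chain instead of shrinking it to a small ring. Going by the values given here, only that one measured step bears on this position, and it shows that a much smaller group costs a great deal in this assay; nothing measured shows what a larger group does. The expectation is therefore that compound 4 stays near compound 2, with a 1.5-fold higher number from compound 2 to compound 4 (0.18 log units; within the scatter) expected to lie within the scatter. Compound 4 is estimated at 1.2 nM in this assay, with a range from 0.4 nM to 4 nM.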

Compound 4, half-maximal effective concentration: 1.8 nM
Compound 4: middle estimate off by 1.5-fold (0.18 log units), on the low side; the range from low to high includes it.
By their numbers in this assay, from the lowest: compounds 2, 1 and 4 (each within the scatter of the next, the first and the last beyond it); then compound 3.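

The pentan-3-yl group on the aromatic nitrogen now has a cost on its larger side as well, since in this assay the move to 1-propylbutyl gives a 2.3-fold higher number from compound 2 to compound 4 (0.35 log units; beyond the scatter). That cost is much smaller than the one seen with cyclopropyl, and the longer branched chain still recovers most of the lost ground, with a 9.2-fold lower number from compound 3 to compound 4 (0.96 log units; beyond the scatter); among these three groups on this nitrogen, pentan-3-yl gives the lowest number, and both other groups give a higher one. No supporting measurement accompanies these values to account for why the number changes with the group at this position.

The three groups leave open what a cyclopentyl or cyclohexyl ring would give on this nitrogen, and whether an isopropyl group would behave more like cyclopropyl or like pentan-3-yl. From the compounds shown here alone, it also remains open whether a chain carrying a hydroxyl group or an amine would be tolerated here, and whether the hydrogen-to-fluoro change on the aromatic carbon would read the same with 1-propylbutyl on the nitrogen.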